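Changing one stereocentre of compound 2

The compounds below may be only part of what the source reports. "The series", "measured", "known", "first", "only" and "open" are said of these compounds alone.

Within the data shown here, in a functional assay for inhibition, with Homo sapiens as the target (on this read-out higher numbers stand for weaker inhibition and lower numbers for stronger inhibition), compound 2 (`O=C(O)COc1cccc(C[C@@H]2CCC[C@H]3O[C@]23c2nc(-c3ccccc3)c(-c3ccccc3)o2)c1`) gives 5.8 nM, the lowest of the three numbers so far. Compound 1 (`O=C(O)COc1cccc(C[C@@H]2CCCC3OC32c2nc(-c3ccccc3)c(-c3ccccc3)o2)c1`) gives 14 nM, and compound 3 (`O=C(O)COc1cccc(C[C@@H]2CCC=CC2(O)c2nc(-c3ccccc3)c(-c3ccccc3)o2)c1`) gives 98 nM. The next compound, compound 4 (`O=C(O)COc1cccc(C[C@@H]2CCC[C@H]3O[C@@]23c2nc(-c3ccccc3)c(-c3ccccc3)o2)c1`), loses nothing and gains nothing compared with compound 2, and only its spatial arrangement changes: the two compounds have the same atoms and bonds and differ only in configuration as drawn: 1 of 3 stereo elements differ; a stereocentre at a saturated ring carbon is drawn R in compound 2 and S in compound 4.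

Among the measured compounds shown here, one measured step bears on this change: a 2.4-fold lower number from compound 1 to compound 2 (0.38 log units; beyond the scatter). It is modest, and the only difference behind it is the fact that one of compounds 1 and 2 is drawn with a defined configuration and the other without, at the place where they differ. So the number does respond to configuration in this series, although no measured pair isolates this single stereocentre. Since compound 2 at 5.8 nM already has the lowest number, a move away from its arrangement is expected to raise the number, probably by more than the scatter, and the size is uncertain. The estimated change is a 6.0-fold higher number from compound 2 to compound 4 (0.78 log units; beyond the scatter). For compound 4 the estimated value is 35 nM, with a likely range from 7 nM to 250 nM.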

Compound 4, half-maximal inhibitory concentration: 12 nM
For compound 4 the middle estimate is 2.9-fold (0.46 log units) above the measured one, within the range that was stated.
By their numbers in this assay, from the lowest: compound 2; then compounds 4 and 1 (each within the scatter of the next); then compound 3.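

Among these compounds, this is the first pair in which one stereocentre at a saturated ring carbon changes on its own, from R in compound 2 to S in compound 4, and in this assay the result is a 2.1-fold higher number from compound 2 to compound 4 (0.32 log units; beyond the scatter). The shift can be assigned to configuration alone, because nothing else separates the two structures: the fact that compounds 2 and 4 differ only in the configuration as drawn. So this centre has a real but modest influence, and the S arrangement keeps a number in the same low range, while the drawing with two undefined centres cannot be told apart from it, with a 1.2-fold lower number from compound 1 to compound 4 (0.07 log units; within the scatter).

The compounds shown leave open what the third stereo element contributes, as no pair changes it alone. They also leave open whether this modest preference for R survives when the carboxylic acid gives way to an amide.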